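The source may hold more compounds than are shown below. What is called first, only, known or untested is meant among the compounds shown, and "the series" means these compounds.

Three compounds with the same core have numbers in a functional assay on MDA-MB-231 cells (Homo sapiens) for antiproliferative activity, read by MTT assay, with a stated time of 72 h; on this read-out lower numbers stand for stronger inhibition and higher numbers for weaker inhibition. Compound 1 `O=S1(=O)C=Cc2cccc(Nc3ccc(OC(F)(F)F)cc3)c21`, which carries trifluoromethoxy, gives 2100 nM. Compound 2 `O=S1(=O)C=Cc2cccc(Nc3ccc(C(F)(F)F)cc3)c21`, which carries trifluoromethyl, gives 1200 nM. Compound 3 `Cc1ccc(Nc2cccc3c2S(=O)(=O)C=C3)cc1`, which carries methyl, gives 1560 nM, and this number lies within the scatter of the other two.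

The next compound is compound 4 `COc1ccc(Nc2cccc3c2S(=O)(=O)C=C3)cc1`, with methoxy in place of methyl on an aromatic carbon, para to a large group: methoxy in place of methyl on an aromatic carbon. Going by the values given here, no measured compound carries methoxy yet, so the closest guide is the three swaps already measured on this same carbon. They are a 1.8-fold lower number from compound 1 to compound 2 (0.24 log units; within the scatter), a 1.3-fold lower number from compound 1 to compound 3 (0.13 log units; within the scatter) and a 1.3-fold higher number from compound 2 to compound 3 (0.11 log units; within the scatter). All three stayed within the scatter, so the new swap is not expected to move the number beyond it in this assay.

The expected change is a 1.0-fold lower number from compound 3 to compound 4 (0.02 log units; within the scatter). Compound 4 is estimated at 1500 nM, with an expected range from 750 nM to 3000 nM.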

Compound 4, half-maximal inhibitory concentration: 1040 nM
Estimate against measurement, compound 4: 1.4-fold (0.16 log units) above, and the stated range covers the measured number.
By their numbers in this assay, from the lowest: compounds 4, 2, 3 and 1 (each within the scatter of the next, the first and the last beyond it).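

In this assay this carbon now shows its first step beyond the scatter, a modest one: a 2.0-fold lower number from compound 1 to compound 4 (0.31 log units; beyond the scatter) when methyl replaces trifluoromethyl on the oxygen. The other two steps stay inside the scatter, a 1.5-fold lower number from compound 3 to compound 4 (0.18 log units; within the scatter) and a 1.2-fold lower number from compound 2 to compound 4 (0.06 log units; within the scatter), so among these four compounds only the pair that both carry an oxygen on this carbon, methoxy and trifluoromethoxy, can be told apart. No measurement shown here bears on why that pair differs.

Going by these compounds alone, what remains open is how far the number can move at this carbon, since every step so far is small. Whether an amine, a carboxylic acid or a longer chain such as ethoxy in this place would stay within the scatter of these four compounds cannot be told from them.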